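Swapping the Amine on the Thiocarbonyl Carbon

The source may report more compounds than this note shows. Statements on the series, on what has been measured and on what is new or still open speak of the compounds shown alone.

Of the compounds shown here, three sharing one core have been measured in a functional assay on A-375 cells (Homo sapiens) for antiproliferative activity, read by CCK-8 assay, with a stated time of 72 h, tested at 2 uM; on this read-out lower numbers stand for a weaker effect and higher numbers for a stronger effect at the one concentration tested. Compound 1 `Nc1ccccc1NC(=O)c1ccc(CSC(=S)N2CCN(c3cccnc3)CC2)cc1` gives 40.5% in this assay, compound 2 `CN(C(=S)SCc1ccc(C(=O)Nc2ccccc2N)cc1)c1cccnc1` gives 26.5%, and compound 3 `CCN(Cc1ccncc1)C(=S)SCc1ccc(C(=O)Nc2ccccc2N)cc1` gives 67.2%. Compound 3 thus stands highest of the three; its nearest neighbour on the numbers is compound 1, and compound 2 sits furthest away. For the measured compounds named here, the only single-point step among them is a number 40.7 percentage points higher from compound 2 to compound 3 (beyond the scatter), which changes the amine on the thiocarbonyl carbon.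

Compound 4 `Nc1ccccc1NC(=O)c1ccc(CSC(=S)N2CCCC2)cc1` has not yet been measured. It differs from compound 3 at the same position: pyrrolidin-1-yl in place of ethyl((pyridin-4-yl)methyl)amino on a thiocarbonyl carbon. Going by the values given here, the earlier step shows that the amine on the thiocarbonyl carbon can shift the read-out a great deal, yet it gives no guide to a pyrrolidin-1-yl group, which no measured compound carries. The three values span a wide range, and compound 4 may fall anywhere within it.

The expectation for compound 4 in this assay is therefore 45%, within a range of 20% to 70%. This estimate means a step of a number 22.2 percentage points lower from compound 3 to compound 4 (beyond the scatter), a downward move toward the middle of the measured spread, held with low confidence.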

Compound 4, a percentage reported as inhibition, at one concentration (the size of the read-out at that concentration, not a potency): 30.2%
Beside the measured number, compound 4's estimate is 14.8 percentage points above it; low and high end bracket the measured number.
By their numbers in this assay, from the lowest: compounds 2 and 4 (each within the scatter of the next); then compound 1; then compound 3.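

In this assay, the change on the thiocarbonyl carbon gives a number 37 percentage points lower from compound 3 to compound 4 (beyond the scatter) and so takes away most of what set compound 3 apart. Pyrrolidin-1-yl is the smaller group by heavy atoms and carries no aromatic ring, and this is the first amine in the set without a pyridinyl group. Yet the comparison with methyl(pyridin-3-yl)amino gives a number 3.7 percentage points higher from compound 2 to compound 4 (within the scatter) so an amine with a pyridinyl group and one without read alike here, which shows that having such a group does not by itself bring a high number at this position. No measurement is available to explain why these amines behave so differently.

The compounds shown leave open which part of ethyl((pyridin-4-yl)methyl)amino goes with the high number of compound 3: the ethyl group or the arm that carries the pyridine ring. A plain diethylamino group, or an ethyl(benzyl)amino group with an all-carbon ring in place of the pyridine ring, would help to pull these two parts apart.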